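Fluoro in Place of Cyano on the Shared Core

The source may hold more compounds than are shown below. What is called first, only, known or untested is meant among the compounds shown, and "the series" means these compounds.

Compound 1 `O=C(Nc1cc(C(F)(F)F)cc(C(F)(F)F)c1)c1cnc(Cl)nc1C(F)(F)F` gives 50 nM in an assay on Jurkat cells for activation of nuclear factor NF-kappa-B complex (Homo sapiens); a higher number here means a weaker inhibitor, a lower number a stronger inhibitor.
Compound 2 `Cc1ncc(C(=O)Nc2cc(C(F)(F)F)cc(C(F)(F)F)c2)c(C(F)(F)F)n1` gives > 10000 nM; > 10000 nM (2 entries) in this assay, a limit and not a number.
Compound 3 `N#Cc1ncc(C(=O)Nc2cc(C(F)(F)F)cc(C(F)(F)F)c2)c(C(F)(F)F)n1` gives > 10000 nM in this assay, again a limit and not a number.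

Three compounds share one core and differ only in the group on one aromatic carbon of that core. Compound 1 carries chloro there and shows a clear number. Compound 2 carries methyl and sits at the limit of > 10000 nM in this assay, at which 1 of the 3 values shown sits. Compound 3 carries cyano and also sits at that limit, so its position is known only as a bound, with a second entry of the same kind.

Within the data shown here, the single measured step that touches compound 3 is an at least 200-fold higher number from compound 1 to compound 3 (2.30 log units; beyond the scatter). Compound 4 `O=C(Nc1cc(C(F)(F)F)cc(C(F)(F)F)c1)c1cnc(F)nc1C(F)(F)F` differs from compound 3 by fluoro in place of cyano on an aromatic carbon. Fluoro is neither the chloro of compound 1 nor the cyano of compound 3, so the measured step gives a direction but not a size. The expectation is a step in the stronger direction, an at least 16-fold lower number from compound 3 to compound 4 (1.22 log units; beyond the scatter), recovering part of what was lost in that step. Compound 4 is therefore estimated at 600 nM, within 60 nM to 10000 nM.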

Compound 4, half-maximal inhibitory concentration: 400 nM
The estimate for compound 4 lay 1.5-fold (0.18 log units) above the measured number; the measured number falls inside the stated range.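

Fluoro on this carbon, which lies between two ring nitrogen atoms, keeps a measurable number in this assay, and the change from cyano gives an at least 25-fold lower number from compound 3 to compound 4 (1.39 log units; beyond the scatter). A measurable number here is therefore not unique to chloro, although the two halogens are not equal, with an 8.0-fold higher number from compound 1 to compound 4 (0.90 log units; beyond the scatter). Of the four groups shown, only chloro and fluoro give a number, while compound 2 with methyl remains a limit of the assay and not a number: the limit of > 10000 nM in this assay, at which 1 of the 4 values shown sits.

The compounds shown leave open whether any other group on this carbon can match chloro or improve on it, and bromo, an amine or a methoxy group would each test that. They also leave open why the two halogens differ from methyl and cyano, and how far compounds 2 and 3 truly lie beyond their limits.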